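A few compounds are considered here, and "the series" means these few. Any claim that something is new, unique, unknown or untested is made for them only; others in the source may bear on it.

Compound 1 `COc1ccc(-c2cc(/C=C/C(=O)c3ccc(N)cc3)[nH]n2)cc1`: -2%
Compound 2 `COc1cc(-c2cc(/C=C/C(=O)c3ccc(N)cc3)[nH]n2)cc(OC)c1OC`: -5%

Of the compounds shown here, two have been measured in a functional assay on MOLT-4 cells (Homo sapiens) for cytotoxicity, read by sulforhodamine B assay, with a stated time of 48 h, tested at 10 uM; a higher number here means a weaker effect of the compound at the concentration tested, a lower number a stronger effect. In this assay compound 1 gives -2% and compound 2 gives -5%. Compound 2 has the lowest of the two numbers, but compound 1 sits only a few points higher, and the two values lie within the scatter of each other, so nothing separates them. Both sit near zero, which means neither compound reduces the growth of the cells to a noticeable degree at the concentration tested.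

The next compound, compound 3 `COc1cc(-c2cc(/C=C/C(=O)c3ccc(Cl)c(Cl)c3)[nH]n2)cc(OC)c1OC`, shares the core of compound 2 and differs from it at one place: 3,4-dichlorophenyl in place of 4-aminophenyl on a carbonyl carbon. Among the measured compounds shown here, no measured pair in this set shows what such a change does in this assay, so the expectation can only rest on the near-zero value of compound 2. Some movement upward is thought possible, yet a step of more than the scatter is far from certain. The expected step is a number 15 percentage points higher from compound 2 to compound 3 (beyond the scatter). For compound 3 the estimate in this assay is 10%, with a likely range from -10% to 40%.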

Compound 3, a percentage reported as activity, at one concentration (the size of the read-out at that concentration, not a potency): 24%
Beside the measured number, compound 3's estimate is 14 percentage points below it; low and high end bracket the measured number.
By their numbers in this assay, from the lowest: compounds 2 and 1 (each within the scatter of the next); then compound 3.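

In this assay, among the compounds shown here, the result of putting 3,4-dichlorophenyl in place of 4-aminophenyl on the carbonyl carbon is a number 29 percentage points higher from compound 2 to compound 3 (beyond the scatter) and it is the first step in this set that can be read at all. Since a higher number here means a weaker effect, the group on this carbonyl carbon does matter to the read-out, and of these two groups 4-aminophenyl goes with the stronger effect. For the compounds shown here, the change is a composite one, though, removing the nitrogen with its counted hydrogen-bond donor and acceptor while adding two chlorines, and nothing measured so far explains the shift.

Going by these compounds, one step cannot show which part of the change carries the difference, so it stays open whether a plain phenyl, a 4-chlorophenyl or a 4-hydroxyphenyl on the same carbonyl carbon would read like compound 2 or like compound 3. On these data alone, it is also open whether the same replacement would move the number similarly on the core of compound 1, which carries a single methoxy group on its other aryl ring.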